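A few compounds are considered here, and "the series" means these few. Any claim that something is new, unique, unknown or untested is made for them only; others in the source may bear on it.

Measured so far:
compound 1 `CC(=O)NCCN(C)c1cccc(OCCCCN)c1`: 0.35
compound 2 `CC(=O)NCCN(C)c1cccc(OCCCCCCN)c1`: 0.08

In a functional assay on cells for agonist activity at melatonin receptor type 1B (Homo sapiens), read by GTPgammaS binding, with a stated time of 30 min (a lower number here means a smaller maximal response, a higher number a larger maximal response), compound 2 stands lowest of the two numbers; the nearest is compound 1, and the one step shown, a number 0.27 lower from compound 1 to compound 2 (beyond the scatter), is beyond the scatter. Compound 3 `CC(=O)NCCN(C)c1cccc(OCCCCOc2cccc(O)c2)c1` is the next member, not yet measured, and differs from compound 2 as follows: 3-hydroxyphenoxy in place of 2-aminoethyl on a saturated chain carbon, four bonds along the chain from an oxygen on an aromatic ring. Within the data shown here, the only measured step bears on it indirectly: it is at the same place on the chain, but there the change was a longer aminoalkyl chain, whereas here the basic amine leaves altogether and an aromatic ring carrying a hydroxyl enters. Nothing measured tells how this assay answers to such an exchange, so no step beyond the scatter is firmly expected, with wide uncertainty either way. The expected step is a number 0.070 higher from compound 2 to compound 3 (within the scatter). Compound 3 is estimated at 0.15, within 0.02 to 0.45.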

Compound 3, intrinsic activity: the largest response reached, as a fraction of the reference agonist's: 0.18
Compound 3: the middle estimate sits 0.030 below what was measured, within the range that was stated.
By their numbers in this assay, from the lowest: compounds 2 and 3 (each within the scatter of the next); then compound 1.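

At this place on the chain, four bonds along the chain from an oxygen on an aromatic ring, a terminal amine is not needed for a measurable response: in this assay compound 3, which carries 3-hydroxyphenoxy and no amine, gives 0.18 as its maximal response. Replacing 2-aminoethyl with 3-hydroxyphenoxy gives a number 0.10 higher from compound 2 to compound 3 (within the scatter) and so does not separate these two groups in this assay, whereas replacing amino with 3-hydroxyphenoxy gives a number 0.17 lower from compound 1 to compound 3 (beyond the scatter) and does separate those two. No measurement at hand accounts for either step.

From the compounds shown here alone, it remains open whether the hydroxyl on the entering ring contributes to the response, which an unsubstituted phenoxy would test. A carboxylic acid at the chain end, or a longer chain carrying 3-hydroxyphenoxy, also remains to be read against these values.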